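Cyclopropyl in place of ethyl on a carbonyl carbon

A few compounds are considered here, and "the series" means these few. Any claim that something is new, unique, unknown or untested is made for them only; others in the source may bear on it.

In an ADME assay (Rattus norvegicus, strain Wistar Han) for pharmacokinetics (on this read-out lower numbers stand for narrower distribution and higher numbers for wider distribution into tissues), compound 1 (`CCn1ncc(-c2nc3c(O[C@H]4CCN(C(=O)C5CCOCC5)C4)ncnc3n2C)c1C`) gives 2 L/kg and compound 2 (`CCC(=O)N1CC[C@H](Nc2ncnc3c2nc(-c2cnn(CC)c2C)n3C)C1`) gives 4 L/kg on the same scale. Going by the values given here, these two numbers lie within the scatter of each other, so compound 2 cannot be separated from compound 1, the only other compound measured so far.

Compound 3 (`CCn1ncc(-c2nc3c(N[C@H]4CCN(C(=O)C5CC5)C4)ncnc3n2C)c1C`) awaits measurement. It differs from compound 2 in one place, with cyclopropyl in place of ethyl on a carbonyl carbon. Among the compounds with values here, no two measured compounds differ in one place only, so the series offers no measured step for sizing this change in this assay. Compound 2 at 4 L/kg is therefore the natural anchor, as the closest measured structure. No step beyond the scatter is expected, and neither direction is favoured. The estimated move is no change at the digits printed from compound 2 to compound 3 (within the scatter) and it is expected to stay within the scatter. Compound 3 is expected at 4 L/kg with an estimated range of 2.2 L/kg to 7 L/kg around that middle.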

Compound 3, volume of distribution: 4 L/kg
For compound 3 middle estimate and measured number coincide at the digits printed; low and high end bracket the measured number.
By their numbers in this assay, from the lowest: compounds 1, 2 and 3 (each within the scatter of the next).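

Notes on the acyl group: in this assay, cyclopropyl in place of ethyl on a carbonyl carbon, whose other neighbour is an amide-type nitrogen in a ring, gives no change at the digits printed from compound 2 to compound 3 (within the scatter). Going by these compounds alone, this is the first measured pair that differs in one place only, so this position now has a direct reading: propanoyl to cyclopropylcarbonyl, which brings in a three-membered non-aromatic ring of carbon only, does not produce a step beyond the scatter on this read-out. No measured evidence on hand bears on why the pair reads this way.

From the compounds shown here alone, a single pair covers only a small exchange at this position, so it remains open whether a longer chain, an amine or a carboxylic acid on the same carbonyl carbon would give a step beyond the scatter. It also remains open whether the exchange of ethyl for cyclopropyl would read the same way in another compound of the series, since the pair of compound 2 and compound 3 is the only example shown.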